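This account rests on a few compounds, and the source may have more. Where it says the series, first, only, none or still open, it means among the compounds named here.

Among the measured compounds shown here, in a functional assay on the whole organism (strain Swiss) with Mus musculus as the target, in the maximal electroshock model, with a stated time of 1 h, at a dose of 300 mg/kg by the intraperitoneal route (a lower number here means a weaker effect, a higher number a stronger effect of the compound at the dose given), compound 2 `CCC(C(=O)N1CCN(c2ccccc2Cl)CC1)N1C(=O)CCC1=O` gives 50%, the highest of the three numbers so far. Compound 1 `CC(C(=O)N1CCN(c2ccc(Cl)cc2)CC1)N1C(=O)CCC1=O` gives 0%, and compound 3 `CCC(C(=O)N1CCN(c2ccccc2C(F)(F)F)CC1)N1C(=O)CCC1=O` gives 0%; both lie well below compound 2. Compound 4 `CCC(C(=O)N1CCN(c2cccc(C)c2)CC1)N1C(=O)CCC1=O` has not yet been measured; it differs from compound 2 in one place: 3-methylphenyl in place of 2-chlorophenyl on an amine nitrogen in a ring. For the measured compounds named here, the only measured step that bears on this change is a number 50 percentage points lower from compound 2 to compound 3 (beyond the scatter), a large loss. Going by the values given here, compound 1 and compound 2 differ in two places, so their values show only that another group on the amine nitrogen in a ring also came with a much weaker result. A drop is therefore expected, a number 30 percentage points lower from compound 2 to compound 4 (beyond the scatter), though with wide uncertainty. Compound 4 is estimated at 20%, between 0% and 60%.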

Compound 4, a percentage reported as activity, at one dose (the size of the read-out at that dose, not a potency): 75%
Beside the measured number, compound 4's estimate is 55 percentage points below it; the measured number lies above the stated range.
By their numbers in this assay, from the lowest: compounds 1 and 3 (each within the scatter of the next); then compound 2; then compound 4.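

In this assay the result is a number 25 percentage points higher from compound 2 to compound 4 (beyond the scatter) and this shows that replacing 2-chlorophenyl on the amine nitrogen need not cost activity, as the earlier trifluoromethyl change did. The change from 2-chlorophenyl to 3-methylphenyl alters the substituent and its numbered ring position together, so the gain cannot be assigned to either one alone. Nothing available explains the gain. As far as these compounds go, it remains open how 2-methylphenyl and 3-chlorophenyl would compare, and these two groups would separate the substituent from its position. Whether a larger group such as 3-methoxyphenyl would keep the gain is also unknown.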